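This account rests on a few compounds, and the source may have more. Where it says the series, first, only, none or still open, it means among the compounds named here.

In an ADME assay on MT4 cells (Homo sapiens) for cytotoxicity, read by MTT assay, with a stated time of 5 days (on this read-out lower numbers stand for higher toxicity in this test and higher numbers for lower toxicity in this test), compound 1 (`COc1ccc(NC(=O)CSc2nc(Nc3c(C)cc(/C=C/C#N)cc3C)c3cc(OC)c(OC)cc3n2)cc1`) reads > 225000 nM, which is a limit of the assay. Compound 2 (`COc1cc2nc([S+]([O-])CC(=O)Nc3ccccc3[N+](=O)[O-])nc(Nc3c(Cl)cc(/C=C/C#N)cc3Cl)c2cc1OC`) reads > 199000 nM, also a limit. Within the data shown here, compound 3 (`COc1cc2nc([S+]([O-])CC(=O)Nc3cccc(F)c3)nc(Nc3c(Cl)cc(/C=C/C#N)cc3Cl)c2cc1OC`) gives 9550 nM, the only actual number so far. Compound 4 (`COc1cc2nc([S+]([O-])CC(=O)Nc3ccc(C#N)cc3)nc(Nc3c(Cl)cc(/C=C/C#N)cc3Cl)c2cc1OC`) is unmeasured and carries 4-cyanophenyl in place of 3-fluorophenyl on an amide-type nitrogen. Among the measured compounds shown here, the only measured step at this nitrogen is an at least 20-fold lower number from compound 2 to compound 3 (1.31 log units; beyond the scatter). That step is large and starts from a limit, so it shows that the group here can matter but fixes no size for the new change. A moderate move towards a higher number is expected, with the direction uncertain. The expected step is a 2.6-fold higher number from compound 3 to compound 4 (0.42 log units; beyond the scatter). For compound 4 the estimated value is 25000 nM, with an expected range of 6000 nM to 150000 nM.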

Compound 4, half-maximal cytotoxic concentration: >= 188000 nM
Compound 4: a limit, no number; the forecaster's own chance of this, stated with the estimate: 35%; middle value at least 7.5-fold (0.87 log units) from the limit.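

In this assay, 4-cyanophenyl in place of 3-fluorophenyl on the amide-type nitrogen gives an at least 19-fold higher number from compound 3 to compound 4 (1.29 log units; beyond the scatter). Of compound 2, compound 3 and compound 4, which differ only at this nitrogen, compound 3 alone gives a number, so the low reading does not extend to every substituted phenyl here. The step from compound 2 to compound 4 cannot be read, with both values being limits.

Still open, on these data alone, is whether the fluorine itself or its place on the ring goes with the low reading, since the two groups differ in both. Also open, as far as these compounds go, is how a phenyl carrying an amine or a carboxylic acid would read.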